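Replacing 3-nitrophenyl with 2,3,4-trifluorophenyl: a small expected step

The source may hold more compounds than are shown below. What is called first, only, known or untested is meant among the compounds shown, and "the series" means these compounds.

Of the compounds shown here, three sharing one core have been measured in a functional assay on DU-145 cells (Homo sapiens) for cytotoxicity, read by MTT assay, with a stated time of 48 h; on this read-out lower numbers stand for stronger inhibition and higher numbers for weaker inhibition: compound 1 `CC(C)=CCC/C(C)=C/CC/C(C)=C/CC[C@@H]1[C@@]2(C)CC/C(=N\OCc3cn(-c4ccccc4)nn3)C(C)(C)[C@@H]2CC[C@@]1(C)O` gives 8830 nM, compound 2 `CC(C)=CCC/C(C)=C/CC/C(C)=C/CC[C@@H]1[C@@]2(C)CC/C(=N\OCc3cn(-c4cccc([N+](=O)[O-])c4)nn3)C(C)(C)[C@@H]2CC[C@@]1(C)O` gives 17400 nM, and compound 3 `CC(C)=CCC/C(C)=C/CC/C(C)=C/CC[C@@H]1[C@@]2(C)CC/C(=N\OCc3cn(-c4cccc(O)c4)nn3)C(C)(C)[C@@H]2CC[C@@]1(C)O` gives 17500 nM. Compound 2 therefore stands within the scatter of both other compounds, and no order can be drawn among the three.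

Compound 4 `CC(C)=CCC/C(C)=C/CC/C(C)=C/CC[C@@H]1[C@@]2(C)CC/C(=N\OCc3cn(-c4ccc(F)c(F)c4F)nn3)C(C)(C)[C@@H]2CC[C@@]1(C)O` differs from compound 2 in a single group: 2,3,4-trifluorophenyl in place of 3-nitrophenyl on an aromatic nitrogen. In words, 2,3,4-trifluorophenyl stands in place of 3-nitrophenyl on an aromatic nitrogen. For the measured compounds named here, three measured steps bear on this change, all of them on the same six-membered aromatic ring. Nitro in place of hydrogen gives a 2.0-fold higher number from compound 1 to compound 2 (0.29 log units; within the scatter), hydroxy in place of hydrogen gives a 2.0-fold higher number from compound 1 to compound 3 (0.30 log units; within the scatter), and hydroxy in place of nitro gives a 1.0-fold higher number from compound 2 to compound 3 (0.00 log units; within the scatter). Going by the values given here, none of these goes beyond the scatter, although no measured compound carries fluorine, so the evidence for this group is only indirect. On these data alone, no step beyond the scatter is therefore expected in this assay, and the direction remains open. The estimated outcome is a 1.3-fold lower number from compound 2 to compound 4 (0.13 log units; within the scatter). For compound 4 the expected value is 13000 nM, with an estimated range from 6000 nM to 28000 nM.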

Compound 4, half-maximal inhibitory concentration: 30400 nM
Compound 4: middle estimate off by 2.3-fold (0.37 log units), on the low side; measured number outside the range, above it.
By their numbers in this assay, from the lowest: compounds 1, 2, 3 and 4 (each within the scatter of the next, the first and the last beyond it).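

In this assay, putting 2,3,4-trifluorophenyl in place of 3-nitrophenyl gives a 1.7-fold higher number from compound 2 to compound 4 (0.24 log units; within the scatter), and putting it in place of 3-hydroxyphenyl gives a 1.7-fold higher number from compound 3 to compound 4 (0.24 log units; within the scatter), so compound 4 cannot be separated from compound 2 or compound 3. Against plain phenyl, however, the new group gives a 3.4-fold higher number from compound 1 to compound 4 (0.54 log units; beyond the scatter), a modest step and the first at this position on the triazole-bearing aromatic nitrogen to pass beyond the scatter, so substitution on this phenyl ring can shift the number upward in this series, whereas the nitro and hydroxy groups alone did not move it past the scatter. Nothing available here accounts for this shift.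

On these data alone, it remains open whether a single fluorine on the phenyl ring would already give such a step, or whether it takes all three, and what an amine or a carboxylic acid on that ring would do to the number. The step also rests on one pair of compounds on the shared core, so whether it would hold on other cells stays unsettled.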